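The source may hold more compounds than are shown below. What is called first, only, known or untested is meant among the compounds shown, and "the series" means these compounds.

Measured compounds in the series:
Compound 1 `CCCCOc1ccc(-c2c(N)nc3ncccn23)cc1`: in a toxicity assay on A549 cells (Homo sapiens) for cytotoxicity, read by luminescence and CellTiter-Glo, with a stated time of 48 h (on this read-out lower numbers stand for higher toxicity in this test and higher numbers for lower toxicity in this test), compound 1 gives > 100000 nM, which is a limit of the assay.
Compound 2 `Nc1nc2ncccn2c1-c1ccc(Br)cc1`: in this assay compound 2 gives > 100000 nM, again a limit.
Compound 3 `COCCOc1ccc(-c2nc3ncccn3c2NC2CCCCC2)cc1`: in this assay compound 3 gives > 100000 nM, also a limit.

Compound 3 therefore stands at a limit only, and so do the other two values shown, all three sitting at the limit of > 100000 nM in this assay, at which 3 of the 3 values shown sit. Among the measured compounds shown here, the single step between compounds that differ in one place, bromo in place of butoxy on an aromatic carbon, reads a step that the two limits leave unreadable from compound 1 to compound 2 and cannot be sized because both ends sit at the limit of > 100000 nM in this assay, at which 3 of the 3 values shown sit.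

Compound 4 `COc1ccc(-c2nc3ncccn3c2NC2CCCCC2)cc1` differs from compound 3 by hydrogen in place of methoxymethyl on a saturated chain carbon bound to an oxygen on an aromatic ring, that is 2-methoxyethoxy to methoxy. For the measured compounds named here, no measured step bears on this change, and the one step available is unreadable. With every value in this assay at a limit, the expected step from compound 3 to compound 4 is a step that the limit leaves unreadable from compound 3 to compound 4, none beyond the scatter. Compound 4 is expected to give 150000 nM, with a range from 60000 nM to 400000 nM, most likely reported again as a limit.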

Compound 4, half-maximal cytotoxic concentration: > 100000 nM
Compound 4 ended at the assay's limit (the forecaster's own chance of this, stated with the estimate: 85%); the middle value does not contradict the limit.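

No new step can be read between compound 3 and compound 4, since both values are limits: the limit of > 100000 nM in this assay, at which 4 of the 4 values shown sit. The compounds shown leave open whether any change on the shared core would give a readable cytotoxic concentration in this assay, and how large such a step would be.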